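Formyl to Carboxy Change Tested on Two Thioether Chains

A few compounds are considered here, and "the series" means these few. Any claim that something is new, unique, unknown or untested is made for them only; others in the source may bear on it.

Measured compounds:
Compound 1 `Cn1c(Cc2nn(CCC=O)c(=O)c3ccccc23)nnc1SCC(=O)Nc1ccc(Cl)cc1Cl`: 30000 nM
Compound 2 `Cn1c(Cc2nn(CCC(=O)O)c(=O)c3ccccc23)nnc1SCC(=O)Nc1ccc(Cl)cc1Cl`: > 30000 nM, a limit of the assay
Compound 3 `Cn1c(Cc2nn(CCC=O)c(=O)c3ccccc23)nnc1SCCCCCCCC(=O)Nc1ccc(Cl)cc1Cl`: 8900 nM

In an assay on 32D cells for inhibition of interleukin-15 (Mus musculus), read by resazurin assay, with stated times of 30 min and 2.5 days, in the presence of a further agent that is not named here (on this read-out lower numbers stand for stronger inhibition and higher numbers for weaker inhibition), compound 1 gives 30000 nM. Compound 2 reaches only a limit of the assay, > 30000 nM (the limit of > 30000 nM in this assay, at which 1 of the 3 values shown sits). Compound 3 gives 8900 nM, the lowest number of the two that were read; the difference between the core of compound 1 and that of compound 3 is not broken down here. The change hydroxy in place of hydrogen on a carbonyl carbon gives a step of a number no lower from compound 1 to compound 2 (the limit leaves the size open).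

Compound 4 `Cn1c(Cc2nn(CCC(=O)O)c(=O)c3ccccc23)nnc1SCCCCCCCC(=O)Nc1ccc(Cl)cc1Cl` carries the same change, (hydroxy in place of hydrogen on a carbonyl carbon), set on the longer chain of compound 3. Because compound 1 to compound 2 shows a number no lower from compound 1 to compound 2 (the limit leaves the size open), a step of similar direction is expected here, a 2.2-fold higher number from compound 3 to compound 4 (0.35 log units; beyond the scatter). Compound 4 is therefore estimated to give 20000 nM, with a range from 8000 nM to 60000 nM.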

Compound 4, half-maximal inhibitory concentration: > 30000 nM
Compound 4 was reported as a limit; the forecaster's own chance of this, stated with the estimate: 35%; middle value at least 1.5-fold (0.17 log units) from the limit.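

On the longer chain, the change from formyl to carboxy in this assay gives an at least 3.3-fold higher number from compound 3 to compound 4 (0.52 log units; beyond the scatter). This shows that the change carried to the second core did not lower the number on either core, but it does not show that the step has the same size on both: the same change on two cores in this assay, a number no lower (the limit leaves the size open) from compound 1 to compound 2 and an at least 3.3-fold higher number (0.52 log units; beyond the scatter) from compound 3 to compound 4; the limit leaves it open whether they differ. Compound 4 stands only as a limit of the assay, and so does compound 2, which means neither step has a known upper size: the limit of > 30000 nM in this assay, at which 2 of the 4 values shown sit.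

From the compounds shown here alone, it remains open what numbers the two carboxy compounds would give if read below that limit. Going by these compounds, it also remains open how an amine or an alcohol in place of the carboxy group would read on either core.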